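A few compounds are considered here, and "the series" means these few. Any claim that something is new, unique, unknown or untested is made for them only; others in the source may bear on it.

Measured so far in an assay on isolated protein for inhibition of protein kinase C delta type (Homo sapiens), read by TR-FRET, with a stated time of 2 h; on this read-out higher numbers stand for weaker inhibition and lower numbers for stronger inhibition:
compound 1, `N#Cc1cnc(NCc2cnccc2C(F)(F)F)cc1NC[C@H]1C[C@H](O)C1`: > 10000 nM
compound 2, `N#Cc1cnc(NCc2cncnc2C(F)(F)F)cc1N[C@H]1CC[C@@H](O)CC1`: 450 nM
compound 3, `N#Cc1cnc(NCc2cncnc2-c2ccccc2)cc1N[C@H]1CC[C@@H](O)CC1`: 90 nM

Compound 1 sits at the limit of this assay (the limit of > 10000 nM in this assay, at which 1 of the 3 values shown sits), so for it only a limit and no number is known. Among the measured compounds shown here, compound 2 and compound 3 both carry a ring attached directly to the ring nitrogen and both give numbers; the single measured step, a 5.0-fold lower number from compound 2 to compound 3 (0.70 log units; beyond the scatter), concerns the group on an aromatic carbon and has no counterpart in the change considered here.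

Compound 4, `CC1(C)[C@@H](Nc2cc(NCc3cnccc3C(F)(F)F)ncc2C#N)C[C@H]1C(N)=O`, differs from compound 1 by 3-carbamoyl-2,2-dimethylcyclobutyl in place of (3-hydroxycyclobutyl)methyl on a nitrogen on an aromatic ring. For the measured compounds named here, no measured pair shows this change, and since compound 1 is known only as a limit, neither direction nor size of the step can be read from the data. The direct attachment of the ring to the nitrogen is shared with compound 2 and compound 3, whose values are known, but this is the only feature they have in common with the change considered here.

The step of an at least 4.0-fold lower number from compound 1 to compound 4 (0.60 log units; beyond the scatter) is an estimate, not a measurement. For compound 4 in this assay the expected value is 2500 nM, with a range from 300 nM to 10000 nM; a limit-only result is also a real possibility.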

Compound 4, half-maximal inhibitory concentration: 4500 nM
For compound 4 the middle estimate is 1.8-fold (0.26 log units) below the measured one; low and high end bracket the measured number.
By their numbers in this assay, from the lowest: compound 3; then compound 2; then compound 4. At a limit, above all of these: compound 1.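

On the core of compound 1, a change at this nitrogen now has a readable effect in this assay: 3-carbamoyl-2,2-dimethylcyclobutyl in place of (3-hydroxycyclobutyl)methyl gives an at least 2.2-fold lower number from compound 1 to compound 4 (0.34 log units; beyond the scatter). With this substituent, the core of compound 1 moves from a limit to a measured number, so the group on this nitrogen matters on this core. The step is only a bound, since compound 1 stands at a limit of the assay: the limit of > 10000 nM in this assay, at which 1 of the 4 values shown sits.

The change alters several features at once, so the compounds shown do not separate the contribution of the direct ring attachment to the nitrogen, the carbamoyl group and the dimethyl substitution. Going by these compounds, how a carboxylic acid or an aminomethyl group in place of the carbamoyl group would read at this position remains open.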